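The source may hold more compounds than are shown below. What is called first, only, known or untested is meant among the compounds shown, and "the series" means these compounds.

Measured in a functional assay on THP-1 cells (Homo sapiens) for cytotoxicity, read by MTT assay, with a stated time of 24 h; a higher number here means a weaker inhibitor, a lower number a stronger inhibitor:
Compound 1 `COc1ccc(/C=C2\CN(C)C/C(=C\c3ccccc3F)C2=O)cc1`: 15400 nM
Compound 2 `COc1cc(/C=C2\CN(C)C/C(=C\c3ccccc3F)C2=O)cc(OC)c1`: 1170 nM
Compound 3 `COc1cc(/C=C2\CN(C)C/C(=C\c3ccc(F)cc3)C2=O)cc(OC)c1`: 5040 nM

Of these three, compound 2 has the lowest number, 1170 nM, and its distance to each of the other two lies beyond the scatter. The next compound, compound 4 `COc1cc(/C=C2\CN(C)C/C(=C\c3ccc(C#N)cc3)C2=O)cc(OC)c1`, has not yet been measured in this assay. It departs from compound 2 in one place: 4-cyanophenyl in place of 2-fluorophenyl on a double-bonded chain carbon bound to a double-bonded ring carbon.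

Within the data shown here, one measured step bears on this change, namely a 4.3-fold higher number from compound 2 to compound 3 (0.63 log units; beyond the scatter). That step also removed the 2-fluorophenyl from the same place, and the group that entered also carries its substituent at the 4 position of the phenyl. Among the measured compounds shown here, it is only a partial guide, since no measured compound carries 4-cyanophenyl. A rise of similar, modest size is therefore expected, with a wide margin. The expected change is a 3.4-fold higher number from compound 2 to compound 4 (0.53 log units; beyond the scatter). For compound 4 the estimated value is 4000 nM, with an expected range of 1500 nM to 11000 nM.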

Compound 4, half-maximal inhibitory concentration: 940 nM
Estimate against measurement, compound 4: 4.3-fold (0.63 log units) above, and the stated range ends above it.
By their numbers in this assay, from the lowest: compounds 4 and 2 (each within the scatter of the next); then compound 3; then compound 1.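

In this assay, the group at this place matters even when its substituent stays at the 4 position of the phenyl: cyano in place of fluoro on an aromatic carbon gives a 5.4-fold lower number from compound 3 to compound 4 (0.73 log units; beyond the scatter). The 4-cyanophenyl and 2-fluorophenyl groups cannot be told apart here, with a 1.2-fold lower number from compound 2 to compound 4 (0.10 log units; within the scatter), so the rise seen with 4-fluorophenyl, a 4.3-fold higher number from compound 2 to compound 3 (0.63 log units; beyond the scatter), does not extend to every phenyl substituted at the 4 position. Nothing at hand explains why cyano and fluoro part ways at this place.

The compounds shown leave open whether this result is particular to the nitrile or would also appear with a 4-aminophenyl or 4-carboxyphenyl group. They also leave open how a 2-cyanophenyl group would compare with the 2-fluorophenyl of compound 2.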